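Ester to amide on a furan-bearing quinazoline scaffold

The source may hold more compounds than are shown below. What is called first, only, known or untested is meant among the compounds shown, and "the series" means these compounds.

Compound 1 `COC(=O)c1oc2ccc(Nc3ncnc4ccc(Cl)nc34)cc2c1C`: > 10000 nM
Compound 2 `O=C(c1cccc(C#Cc2ccccc2Nc2ncnc3ccc(Cl)nc23)c1)N1CCNCC1`: > 10000 nM

In an assay on isolated protein for inhibition of MAP kinase-interacting serine/threonine-protein kinase 1 (Homo sapiens), read by HTRF, in the presence of a further agent that is not named here (on this read-out lower numbers stand for stronger inhibition and higher numbers for weaker inhibition), compound 1 gives > 10000 nM, which is a limit of the assay rather than a number. Compound 2 likewise gives only the limit > 10000 nM. Both values therefore sit at the same boundary, as shown by the limit of > 10000 nM in this assay, at which 2 of the 2 values shown sit, so compound 1 cannot be ranked against compound 2.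

Compound 3 `CNC(=O)c1oc2ccc(Nc3ncnc4ccc(Cl)nc34)cc2c1C` differs from compound 1 by methylamino in place of methoxy on a carbonyl carbon. Nothing measured between these compounds shows the size of such a change. The step that the limit leaves unreadable from compound 1 to compound 3 is expected to stay within the scatter. Compound 3 is expected to give 20000 nM, estimated between 5000 nM and 100000 nM.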

Compound 3, half-maximal inhibitory concentration: > 10000 nM
Compound 3 ended at the assay's limit; the forecaster's own chance of this, stated with the estimate: 80%; the middle value is on the limit's open side.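

No step can be read from compound 1 to compound 3, as both values are limits of the assay. The compounds shown leave open whether, in this assay methylamino in place of methoxy on a carbonyl carbon changes inhibition at all.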